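Methyl in Place of the Aryl Group on the Ring Nitrogen

The source may hold more compounds than are shown below. What is called first, only, known or untested is meant among the compounds shown, and "the series" means these compounds.

Compound 1 `CC(C)C1(C(C)C)NC(=O)N(CN2CCN(c3ccccc3)CC2)C1=O`: 300 mg/kg
Compound 2 `CC(C)C1(C(C)C)NC(=O)N(CN2CCN(c3cccc(C(F)(F)F)c3)CC2)C1=O`: 100 mg/kg
Compound 3 `O=C1NC(c2ccccc2)(c2ccccc2)C(=O)N1CN1CCN(c2ccccc2F)CC1`: 30 mg/kg

All three were tested in a functional assay on the whole organism (strain CD1) with Mus musculus as the target, in the maximal electroshock model, with a stated time of 4 h; a lower number here means that less compound is needed, a higher number that more compound is needed for the effect. Compound 3 stands lowest of the three numbers; compound 2 is the nearest to it, and compound 1 the furthest, both beyond the scatter. Among the measured compounds shown here, the only step between two compounds that differ in one place, a 3.0-fold lower number from compound 1 to compound 2 (0.48 log units; beyond the scatter), concerns trifluoromethyl in place of hydrogen on an aromatic carbon.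

Compound 4 `CN1CCN(CN2C(=O)NC(c3ccccc3)(c3ccccc3)C2=O)CC1` differs from compound 3 as follows: methyl in place of 2-fluorophenyl on an amine nitrogen in a ring. Here the whole aromatic ring on the ring nitrogen is lost, not merely decorated, so the one measured step does not bear directly on this change; it shows only that what sits on that ring matters beyond the scatter. With the aromatic ring removed, the step from compound 3 to compound 4 is expected to go toward a higher number, and its expected size is a 3.3-fold higher number from compound 3 to compound 4 (0.52 log units; beyond the scatter). Compound 4 is therefore estimated at 100 mg/kg, within a range from 30 mg/kg to 300 mg/kg.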

Compound 4, minimum effective dose: 10 mg/kg
Beside the measured number, compound 4's estimate is 10-fold (1.00 log units) above it, and the stated range ends above it.
By their numbers in this assay, from the lowest: compound 4; then compound 3; then compound 2; then compound 1.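

The change from 2-fluorophenyl to methyl on the amine nitrogen gives a 3.0-fold lower number from compound 3 to compound 4 (0.48 log units; beyond the scatter) in this assay, so less compound is needed once the aromatic ring is gone. The earlier step showed only that a substituent on that aromatic ring can shift the number; this one shows that, on the core of compound 3, the effect does not depend on an aromatic ring at this position. No measurement shown here accounts for the change in the number.

Going by these compounds, it remains open whether an ethyl group, a longer chain or a plain hydrogen on that ring nitrogen would keep the lower number. On these data alone, it also remains open whether methyl in place of the aromatic ring would shift the number in the same direction on the core of compound 1.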